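The compounds below may be only part of what the source reports. "The series", "measured", "known", "first", "only" and "open" are said of these compounds alone.

Measured so far in a functional assay on the whole organism (strain CD1) with Mus musculus as the target, in the maximal electroshock model, with a stated time of 4 h; a higher number here means that more compound is needed for the effect, a lower number that less compound is needed:
- compound 1 `CC1CC(=O)N(CC(=O)N2CCN(c3ccc(Cl)cc3)CC2)C1=O`: 30 mg/kg
- compound 2 `CC1CC(=O)N(CC(=O)N2CCN(c3cccc(Cl)c3)CC2)C1=O`: 300 mg/kg

Among the compounds with values here, compound 2 stands at the highest of the two numbers in this assay; its nearest neighbour is compound 1, and the only measured step, a 10-fold higher number from compound 1 to compound 2 (1.00 log units; beyond the scatter), is what separates them. That step is a move of chloro from one ring position to another, with the group itself unchanged.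

Compound 3 `CC1CC(=O)N(CC(=O)N2CCN(c3cccc(C(F)(F)F)c3)CC2)C1=O` is the next member and has not yet been measured in this assay. Its difference from compound 2 is a single one: trifluoromethyl in place of chloro on an aromatic carbon. Within the data shown here, no measured step describes an exchange of the substituent at a fixed position, so the step of a 10-fold higher number from compound 1 to compound 2 (1.00 log units; beyond the scatter) bears on the new compound only loosely, showing that the number in this assay does respond to what sits on the phenyl ring, and by how much. Among the measured compounds shown here, with no direct precedent, the working expectation for compound 3 is a step of no change at the digits printed from compound 2 to compound 3 (within the scatter), that is, nothing beyond the scatter, with a wide band on either side. Compound 3 is therefore estimated at 300 mg/kg, in the range 100 mg/kg to 1000 mg/kg.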

Compound 3, minimum effective dose: 100 mg/kg
The estimate for compound 3 lay 3.0-fold (0.48 log units) above the measured number, and the stated range covers the measured number.
By their numbers in this assay, from the lowest: compound 1; then compound 3; then compound 2.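

Exchanging chloro for trifluoromethyl on the same aromatic carbon, meta to a large group, gives a 3.0-fold lower number from compound 2 to compound 3 (0.48 log units; beyond the scatter) in this assay. Within the data shown here, the earlier compounds showed only that moving chloro changes the number; this exchange shows that, with the place kept, the identity of the group also changes the number beyond the scatter, and that less compound is needed with trifluoromethyl here than with chloro. No accompanying measurement bears on this change, so the step stands as an observation without an explanation.

Compound 1 and compound 3 differ in more than one place, so the compounds shown cannot say whether trifluoromethyl in place of chloro would give a step of the same direction or size in the 4-chlorophenyl setting of compound 1. Also open, on these data alone, is how a methoxy group, an amine or a carboxylic acid on this aromatic carbon would read, since two substituents at this place give no trend that could be carried over to other groups.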